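This account rests on a few compounds, and the source may have more. Where it says the series, first, only, none or still open, it means among the compounds named here.

Compound 1 `Cc1cc(/C=C/C(=O)NCCn2c(C(F)(F)F)cc3ccccc32)cc(C)c1F` was tested in an assay on C6 cells for antagonist activity at prostaglandin E2 receptor EP2 subtype (Homo sapiens), read by TR-FRET, with stated times of 10 min and 40 min, tested at 1 uM (on this read-out lower numbers stand for stronger inhibition and higher numbers for weaker inhibition), where compound 1 gives 306 nM. Compound 2 `COc1ccc(/C=C/C(=O)NCCn2c(C(F)(F)F)cc3ccccc32)cc1` gives 305 nM in this assay, and the step of a 1.0-fold lower number from compound 1 to compound 2 (0.00 log units; within the scatter) shows that compound 1 stands alongside compound 2 rather than apart from it. Compound 3 `Cc1cc(/C=C/C(=O)NCCn2c(C)cc3ccccc32)cc(C)c1F` differs from compound 1 in methyl in place of trifluoromethyl on an aromatic carbon. For the measured compounds named here, the only measured step alters the aryl end of the chain, not this part of the shared core, so no measured step bears on the change to compound 3. With no guide, compound 3 is expected to sit near compound 1, the estimated step from compound 1 to compound 3 being a 1.1-fold higher number from compound 1 to compound 3 (0.06 log units; within the scatter). The estimate for compound 3 in this assay is 350 nM, within the range 90 nM to 1500 nM.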

Compound 3, antagonist equilibrium constant: 3.4 nM
Beside the measured number, compound 3's estimate is 100-fold (2.01 log units) above it; measured number outside the range, below it.
By their numbers in this assay, from the lowest: compound 3; then compounds 2 and 1 (each within the scatter of the next).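

In this assay, methyl in place of trifluoromethyl on this aromatic carbon, next to the ring nitrogen, gives a 90-fold lower number from compound 1 to compound 3 (1.95 log units; beyond the scatter) and so shows that this position matters far more than the earlier change at the aryl end, which stayed within the scatter. No measurement shown here explains this large shift.

Still open, on these data alone, is whether methyl itself is needed, or whether hydrogen, chlorine or an ethyl group on this carbon would give a similar number. Also open, as far as these compounds go, is whether the same change holds with the 4-methoxyphenyl end of compound 2.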